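Working notes: tolerated concentration in a small hydrazide series

The source may report more compounds than this note shows. Statements on the series, on what has been measured and on what is new or still open speak of the compounds shown alone.

Measured in an ADME assay on MT4 cells (Homo sapiens) for cytotoxicity, read by MTT assay, with a stated time of 4 days; a lower number here means that less compound is tolerated, a higher number that more compound is tolerated:
compound 1 `O=C(COc1cccc2ccccc12)N/N=C/c1ccccc1Br`: 11.4 ug/mL
compound 2 `COc1cc(/C=N/NC(=O)COc2cccc3ccccc23)cc(OC)c1OC`: 13.4 ug/mL
compound 3 `O=C(COc1cccc2ccccc12)N/N=C/c1ccccc1[N+](=O)[O-]`: 12.2 ug/mL

Compound 1 gives the lowest of the three numbers, but the spread is narrow: the step of a 1.1-fold higher number from compound 1 to compound 3 (0.03 log units; within the scatter) is within the scatter, and compound 2 sits within the scatter of compound 1 as well. Compound 4 `O=C(COc1cccc2ccccc12)N/N=C/c1cccc(Cl)c1` differs from compound 1 by 3-chlorophenyl in place of 2-bromophenyl on a carbon with a double bond to nitrogen. For the measured compounds named here, the only measured step that touches the same aromatic group is a 1.1-fold higher number from compound 1 to compound 3 (0.03 log units; within the scatter), and it was within the scatter; no other change on this group has been measured. The expected step is therefore none beyond the scatter, a 1.1-fold higher number from compound 1 to compound 4 (0.02 log units; within the scatter). Compound 4 is estimated at 12 ug/mL in this assay, with a range from 7 ug/mL to 20 ug/mL.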

Compound 4, half-maximal cytotoxic concentration: 89.9 ug/mL
Estimate against measurement, compound 4: 7.5-fold (0.87 log units) below; the measured number lies above the stated range.
By their numbers in this assay, from the lowest: compounds 1, 3 and 2 (each within the scatter of the next); then compound 4.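

In this assay, 3-chlorophenyl in place of 2-bromophenyl on a carbon with a double bond to nitrogen gives a 7.9-fold higher number from compound 1 to compound 4 (0.90 log units; beyond the scatter), the only step shown that lies beyond the scatter. This position can therefore move the tolerated concentration, which the nitro for bromo change, a 1.1-fold higher number from compound 1 to compound 3 (0.03 log units; within the scatter), did not show. Nothing available bears on what lies behind this step. The halogen and its place change together in compound 4, leaving open which of them matters; 2-chlorophenyl and 3-bromophenyl would separate the two. From the compounds shown here alone, how an amine or a carboxylic acid on this aromatic group would read also remains open.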